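Series notes: from compound 2 toward compound 3

The compounds below may be only part of what the source reports. "The series", "measured", "known", "first", "only" and "open" are said of these compounds alone.

Two compounds of the shared core have been run in a functional assay on the whole organism with Rattus norvegicus as the target; on this read-out lower numbers stand for an effect already at smaller amounts and higher numbers for an effect only at larger amounts of compound. Compound 1 `CCCCCCCc1ccc2nc(N)sc2c1` gives only a limit there, > 10 mg/kg, which is not a number. One of the two values shown, that of compound 1, is the limit of > 10 mg/kg in this assay, at which 1 of the 2 values shown sits. Going by the values given here, compound 2 `C#CCn1c(=N)sc2cc(OC(F)(F)F)ccc21` gives 4 mg/kg in this assay, the only number in the set. Compound 3 `N=c1sc2cc(OC(F)(F)F)ccc2n1CCSc1ccccc1` is not yet measured; it differs from compound 2 by (phenylsulfanyl)methyl in place of ethynyl on a saturated chain carbon bound to an aromatic nitrogen. Among the compounds with values here, no step between measured compounds exists, so the step of a 1.3-fold higher number from compound 2 to compound 3 (0.10 log units; within the scatter) is estimated as none beyond the usual scatter. Compound 3 is expected at 5 mg/kg, with a range from 2 mg/kg to 15 mg/kg.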

Compound 3, dose for half-maximal effect: 4.5 mg/kg
The estimate for compound 3 lay 1.1-fold (0.05 log units) above the measured number; the range from low to high includes it.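

In this assay, (phenylsulfanyl)methyl in place of ethynyl on a saturated chain carbon bound to an aromatic nitrogen gives a 1.1-fold higher number from compound 2 to compound 3 (0.05 log units; within the scatter) in this series. This place thus accepts a far larger group carrying a six-membered aromatic ring and a sulfur, and the triple bond of ethynyl is not required for a value of this size. No measured property shown here bears on this result.

On these data alone, whether an amine or a carboxylic acid at this place would keep the value stays open. So does the effect of a longer chain ahead of the sulfur.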